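A few compounds are considered here, and "the series" means these few. Any claim that something is new, unique, unknown or untested is made for them only; others in the source may bear on it.

Measured in a physicochemical assay for lipophilicity, read by LC-MS, in phosphate buffer, measured as octanol-water partition, with a stated time of 30 min, at pH 7.4, tested at 200 mM; a lower number here means a more polar compound, a higher number a more lipophilic compound:
compound 1 `Cn1c(COc2cccc(C(=O)O)c2)nc2ccc(Oc3ccccn3)cc21`: 0.4
compound 2 `Cn1c(COc2cccc(C(=O)O)c2)nc2ccc(Oc3cc(Cl)ccn3)cc21`: 1.2
compound 3 `Cn1c(COc2cccc(C(=O)O)c2)nc2ccc(Oc3ccc(F)cn3)cc21`: 0.6

Compound 3 sits second highest of the three numbers. Its nearest neighbour is compound 1, with a number 0.20 log units higher from compound 1 to compound 3 (within the scatter), a gap within the scatter; its furthest is compound 2, with a number 0.60 log units lower from compound 2 to compound 3 (beyond the scatter), a gap beyond the scatter.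

Compound 4 `Cc1cc(F)cnc1Oc1ccc2nc(COc3cccc(C(=O)O)c3)n(C)c2c1` is not yet measured in this assay. It differs from compound 3 by methyl in place of hydrogen on an aromatic carbon: a methyl enters on an aromatic carbon of the six-membered aromatic ring with one nitrogen, ortho to a large group, two atoms from the ring nitrogen, meta to the fluoro group.

Among the compounds with values here, no measured step adds a methyl. The steps that add one heavy atom on an aromatic carbon of the same ring are halogen additions: chloro gave a number 0.80 log units higher from compound 1 to compound 2 (beyond the scatter), fluoro gave a number 0.20 log units higher from compound 1 to compound 3 (within the scatter). A single-carbon addition is expected to move this assay in the same direction, by a modest amount, most likely between the two halogen steps.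

For compound 4 the expected step is a number 0.50 log units higher from compound 3 to compound 4 (beyond the scatter), giving an estimated value of 1.1, with a range from 0.7 to 1.5.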

Compound 4, distribution coefficient: 1.1
Estimate against measurement, compound 4: no gap at the digits printed; low and high end bracket the measured number.
By their numbers in this assay, from the lowest: compounds 1 and 3 (each within the scatter of the next); then compounds 4 and 2 (each within the scatter of the next).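

In this assay methyl in place of hydrogen gives a number 0.50 log units higher from compound 3 to compound 4 (beyond the scatter) at the aromatic carbon ortho to a large group and two atoms from the ring nitrogen, showing that this position can carry a step beyond the scatter on a ring that already holds a fluoro group. Read from the unsubstituted ring, 5-fluoro-3-methylpyridin-2-yl in place of pyridin-2-yl gives a number 0.70 log units higher from compound 1 to compound 4 (beyond the scatter) and so reaches a step beyond the scatter, whereas fluoro alone gave a number 0.20 log units higher from compound 1 to compound 3 (within the scatter) and stayed within it. 5-Fluoro-3-methylpyridin-2-yl in place of 4-chloropyridin-2-yl gives a number 0.10 log units lower from compound 2 to compound 4 (within the scatter), so these two substituted rings cannot be told apart in this read-out even though their substituents differ in kind and in place.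

The compounds shown leave open whether methyl gives a step of the same size on the ring without the fluoro group, and whether an ethyl, a methoxy or an amine at this position would move the number further. Nothing shown accounts for the size of any of these steps.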